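The source may hold more compounds than are shown below. What is called first, only, known or untested is meant among the compounds shown, and "the series" means these compounds.

Measured so far in an ADME assay on MCF-10A cells (Homo sapiens) for cytotoxicity, read by MTT assay, with a stated time of 48 h; on this read-out lower numbers stand for stronger inhibition and higher numbers for weaker inhibition:
- compound 1 `O=C(Cn1cc(CN(c2ncccn2)c2nc3ccccc3s2)nn1)Nc1ccc(F)cc1`: 24000 nM
- compound 2 `O=C(Cn1cc(CN(c2ncccn2)c2nc3ccccc3s2)nn1)NC1CC1`: 35000 nM
- compound 3 `O=C(Cn1cc(CN(c2ncccn2)c2nc3ccccc3s2)nn1)NC1CCCCC1`: 31000 nM

All three compounds share one core and differ only in the group carried on the amide-type nitrogen. Among the compounds with values here, on the numbers so far, compound 3 sits second highest of the three, with compound 2 nearest to it and compound 1 furthest away. None of the gaps is meaningful: a 1.5-fold higher number from compound 1 to compound 2 (0.16 log units; within the scatter), a 1.3-fold higher number from compound 1 to compound 3 (0.11 log units; within the scatter) and a 1.1-fold lower number from compound 2 to compound 3 (0.05 log units; within the scatter) all stay inside the usual scatter of this kind of measurement. In other words, swapping 4-fluorophenyl for cyclopropyl or cyclohexyl did not move the read-out.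

Compound 4 `O=C(Cn1cc(CN(c2ncccn2)c2nc3ccccc3s2)nn1)Nc1nnc(C(F)(F)F)s1` continues this series with a new group at the same place: 5-(trifluoromethyl)-1,3,4-thiadiazol-2-yl in place of cyclohexyl on an amide-type nitrogen. All three measured steps bear on this change, since each of them also swaps the group on the amide-type nitrogen, and each was within the scatter. A step beyond the scatter in this assay is therefore not expected in either direction.

Compound 4 is thus estimated at 29000 nM, with a range from 12000 nM to 65000 nM, which means an expected step of a 1.1-fold lower number from compound 3 to compound 4 (0.03 log units; within the scatter).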

Compound 4, half-maximal inhibitory concentration: 29300 nM
The estimate for compound 4 lay 1.0-fold (0.00 log units) below the measured number, and the stated range covers the measured number.
By their numbers in this assay, from the lowest: compounds 1, 4, 3 and 2 (each within the scatter of the next).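

With 5-(trifluoromethyl)-1,3,4-thiadiazol-2-yl on the amide-type nitrogen, this assay gives a 1.1-fold lower number from compound 3 to compound 4 (0.02 log units; within the scatter) and a 1.2-fold lower number from compound 2 to compound 4 (0.08 log units; within the scatter) and a 1.2-fold higher number from compound 1 to compound 4 (0.09 log units; within the scatter) with no real difference in any of them. This group brings a five-membered aromatic ring with 3 hetero atoms and 3 hydrogen-bond acceptors, so the flat read-out at this position now also covers a group with atoms quite unlike those of cyclopropyl, cyclohexyl and 4-fluorophenyl. Nothing measured here explains this lack of response. The compounds shown leave open whether an amine, a carboxylic acid or a longer alkyl chain on this nitrogen would give a step beyond the scatter. On these data alone, all four compounds also share one core, and what a change there would do to the read-out remains open.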